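This account rests on a few compounds, and the source may have more. Where it says the series, first, only, none or still open, it means among the compounds named here.

The measured compounds and their values:
Compound 1, `CCCCCc1ccc(C#Cc2c(-c3ccc(CCCCC)cc3)oc3nc(=O)n(Cc4cn(-c5ccccc5F)nn4)cc23)cc1`, in a functional assay on HeLa cells (Homo sapiens) for antiproliferative activity, read by MTT assay, with a stated time of 72 h (a lower number here means a stronger inhibitor, a higher number a weaker inhibitor), gives 9000 nM.
Compound 2, `CCCCCCc1cc2cn(Cc3cn(-c4ccccc4F)nn3)c(=O)nc2o1`, in this assay reaches > 100000 nM, which is a limit and not a number.
Compound 3, `O=c1nc2oc(CCCCl)cc2cn1Cc1cn(-c2ccccc2F)nn1`, in this assay gives 66500 nM.

Compound 2 thus stands at the edge of what this assay reports, as shown by the limit of > 100000 nM in this assay, at which 1 of the 3 values shown sits. Compound 3, with chloro in place of propyl on a saturated chain carbon, three bonds along the chain from an aromatic carbon, is separated from it by an at least 1.5-fold lower number from compound 2 to compound 3 (0.17 log units; that floor lies within the scatter), and that floor lies within the scatter.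

Compound 4, `CCCCCCc1cc2cn(Cc3cn(Cc4ccccc4)nn3)c(=O)nc2o1`, is not yet measured. It differs from compound 2 by benzyl in place of 2-fluorophenyl on an aromatic nitrogen of a five-membered aromatic ring with three nitrogen. For the measured compounds named here, no measured step bears on this position; the only step known, from compound 2 to compound 3, changes the chain group and not the aromatic nitrogen. Nothing measured therefore supports a step in this assay beyond the scatter, in either direction. Compound 4 is expected to sit near the limit, at 100000 nM, within 30000 nM to 300000 nM. This estimate means an expected step of a number no higher from compound 2 to compound 4 (the limit leaves the size open).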

Compound 4, half-maximal inhibitory concentration: 59400 nM
Beside the measured number, compound 4's estimate is 1.7-fold (0.23 log units) above it; the measured number falls inside the stated range.
By their numbers in this assay, from the lowest: compound 1; then compounds 4 and 3 (each within the scatter of the next). At a limit, above all of these: compound 2.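

For the compounds shown here, this is the first change at the aromatic nitrogen of the five-membered aromatic ring with 3 nitrogen, since the earlier step touched only the chain group. In this assay, benzyl in place of 2-fluorophenyl on that nitrogen gives an at least 1.6-fold lower number from compound 2 to compound 4 (0.22 log units; that floor lies within the scatter), so the change cannot be called a real shift, although compound 4 gives a readable number of 59400 nM with the chain of compound 2 kept in place. The true size of the step stays open because compound 2 stands at a limit and not at a number: the limit of > 100000 nM in this assay, at which 1 of the 4 values shown sits.

The compounds shown leave open whether any other group on this nitrogen, such as a plain phenyl, a 2-phenylethyl chain or a benzyl carrying an amine or a carboxylic acid, would move the number beyond the scatter in either direction. They also leave open whether benzyl in place of 2-fluorophenyl would do the same on the chloro-bearing chain of compound 3 or on the larger frame of compound 1, where the same 2-fluorophenyl group sits.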